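Furan-2-yl to 2-Hydroxyethyl: What to Expect for Compound 4

The compounds below may be only part of what the source reports. "The series", "measured", "known", "first", "only" and "open" are said of these compounds alone.

Measured compounds:
compound 1, `NS(=O)(=O)Oc1ccc2c(c1)CN(C(=O)c1ccc(N(Cc3ccccc3)Cc3ccco3)cc1)CC2`: 90.8%
compound 2, `CN(CCCN1CCCCC1)c1cccc(C(=O)N2CCc3ccc(OS(N)(=O)=O)cc3C2)c1`: 24.1%
compound 3, `CN(C)CCN(CCN(C)C)c1cccc(C(=O)N2CCc3ccc(OS(N)(=O)=O)cc3C2)c1`: 0%

In an assay on HEK293 cells for inhibition of Steryl-sulfatase (Homo sapiens), tested at 0.1 uM (a higher number here means a stronger effect of the compound at the concentration tested, a lower number a weaker effect), compound 1 gives 90.8%, the highest of the three numbers. Compound 2 gives 24.1%, which lies beyond the scatter below compound 1, and compound 3 gives 0%, the furthest from compound 1 of the three. Among the compounds with values here, the one step between measured compounds, a number 24.1 percentage points lower from compound 2 to compound 3 (beyond the scatter), concerns an exchange of the whole amine substituent on the aromatic ring and is modest in size.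

Compound 4, `NS(=O)(=O)Oc1ccc2c(c1)CN(C(=O)c1ccc(N(CCCO)Cc3ccccc3)cc1)CC2`, is not yet measured. It differs from compound 1 as 2-hydroxyethyl in place of furan-2-yl on a saturated chain carbon bound to a nitrogen on an aromatic ring. Within the data shown here, no measured step touches this position on the shared core of compound 1, so the only guidance is that compound 1 sits high and that the one recorded exchange of an amine substituent, a number 24.1 percentage points lower from compound 2 to compound 3 (beyond the scatter), lowered the read-out by a modest amount. A decrease of similar size, or none beyond the scatter, is therefore expected, and the estimate for compound 4 is 75% with a range from 45% to 95%, which corresponds to an expected step of a number 15.8 percentage points lower from compound 1 to compound 4 (beyond the scatter).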

Compound 4, a percentage reported as inhibition, at one concentration (the size of the read-out at that concentration, not a potency): 5.7%
Beside the measured number, compound 4's estimate is 69.3 percentage points above it; measured number outside the range, below it.
By their numbers in this assay, from the lowest: compounds 3 and 4 (each within the scatter of the next); then compound 2; then compound 1.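

In this assay, within the data shown here, replacing furan-2-yl with 2-hydroxyethyl on a saturated chain carbon bound to a nitrogen on an aromatic ring gives a number 85.1 percentage points lower from compound 1 to compound 4 (beyond the scatter), a large step and the first measured change at this position. The rest of compound 1 stays the same, so the read-out depends strongly on this one group: the whole loss comes with an exchange in which a five-membered aromatic ring with 1 hetero atom leaves and a chain with no ring and 1 hydrogen-bond donor enters. Nothing measured here bears on why the read-out falls so far.

Among these compounds, the single pair does not separate the loss of the ring from the arrival of the hydroxyl group, as both change in the same step. On these data alone, whether a plain propyl chain, with no hydroxyl group, or a thiophene ring in place of the furan would keep the read-out close to that of compound 1, which gives 90.8%, remains open.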